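The compounds below may be only part of what the source reports. "The series", "measured", "known", "first", "only" and "open" are said of these compounds alone.

Measured so far in a physicochemical assay for lipophilicity, using the shake flask method, measured as octanol-water partition, at pH 7.4; a higher number here means a more lipophilic compound, a lower number a more polar compound:
- compound 1 `CC(=O)N[C@@H]1CCC[C@H](C(=O)Nc2cc(-c3cnn4c3CCCC4)c(Cl)cn2)C1` gives 3.2
- compound 2 `CC(=O)N[C@@H]1CCC[C@H](C(=O)Nc2cc(-c3cnn4c3COCC4)c(Cl)cn2)C1` gives 2.4

Compound 2, at 2.4, holds the lower of the two numbers. Compound 3 `CC(=O)N[C@@H]1CCC[C@H](C(=O)Nc2cc(-c3cnn4c3CN(C)CC4)c(Cl)cn2)C1` differs from it by a group of 10 heavy atoms (7 carbon, 3 nitrogen; one five-membered aromatic ring with 2 hetero atoms, one six-membered non-aromatic ring with 2 hetero atoms) in place of a group of 9 heavy atoms (6 carbon, 2 nitrogen, 1 oxygen; one five-membered aromatic ring with 2 hetero atoms, one six-membered non-aromatic ring with 2 hetero atoms), on an aromatic carbon, opposite the ring nitrogen. Among the measured compounds shown here, the one measured step bearing on this is a number 0.80 log units lower from compound 1 to compound 2 (beyond the scatter) at the same aromatic carbon. It shows that the number can move with this group, but it is a different exchange and gives no direct size. A small move is expected, namely a number 0.10 log units higher from compound 2 to compound 3 (within the scatter) as the estimate. For compound 3 the estimated value is 2.5 with 2.1 to 3 as the expected range.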

Compound 3, distribution coefficient: 2.1
For compound 3 the middle estimate is 0.40 log units above the measured one, within the range that was stated.
By their numbers in this assay, from the lowest: compounds 3 and 2 (each within the scatter of the next); then compound 1.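

In this assay, the group of 10 heavy atoms gives a number 0.30 log units lower from compound 2 to compound 3 (within the scatter), so at this aromatic carbon the two groups with 2 hetero atoms in the six-membered ring are not told apart. Set against the group of compound 1, it gives a number 1.10 log units lower from compound 1 to compound 3 (beyond the scatter), which shows that a second such ring also lies beyond the scatter from compound 1. Nothing available explains these steps. On these data alone, what remains open is how the number would respond to a sulfone or a carboxylic acid on this six-membered ring.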